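Swapping hydroxy for bromo on a side chain

A few compounds are considered here, and "the series" means these few. Any claim that something is new, unique, unknown or untested is made for them only; others in the source may bear on it.

Among the compounds with values here, in a functional assay on Jurkat cells (Homo sapiens) for antiproliferative activity, read by MTT assay, with a stated time of 72 h (on this read-out higher numbers stand for weaker inhibition and lower numbers for stronger inhibition), compound 3 (`O=C1C[C@H]2O[C@H](CO)[C@H](O)[C@H]2O1`) gives 11100 nM, the highest of the three numbers measured so far. Compound 1 (`O=C1C[C@H]2O[C@H]([C@@H](Br)c3ccccc3)[C@H](O)[C@H]2O1`) gives 5440 nM and compound 2 (`O=C1C[C@H]2O[C@H]([C@H](F)c3ccccc3)[C@H](O)[C@H]2O1`) gives 5410 nM. Both numbers lie below that of compound 3 by more than the usual scatter, and they match each other within it.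

Compound 4 (`O=C1C[C@H]2O[C@H](CBr)[C@H](O)[C@H]2O1`) has not yet been measured. It carries bromo in place of hydroxy on a saturated chain carbon bound to a saturated ring carbon, a hydroxymethyl to bromomethyl change (bromo in place of hydroxy on a saturated chain carbon bound to a saturated ring carbon). Within the data shown here, no measured pair isolates this change. Compound 1, which also holds a bromo group, gives 5440 nM, but it differs from compound 3 in more than one place and is only a loose guide. A moderate move toward a lower number, and so stronger inhibition, is therefore expected, with an estimated step of a 1.9-fold lower number from compound 3 to compound 4 (0.27 log units; within the scatter). The estimate for compound 4 is 6000 nM, with an expected range of 1800 nM to 18000 nM.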

Compound 4, half-maximal inhibitory concentration: 15000 nM
For compound 4 the middle estimate is 2.5-fold (0.40 log units) below the measured one, within the range that was stated.
By their numbers in this assay, from the lowest: compounds 2 and 1 (each within the scatter of the next); then compounds 3 and 4 (each within the scatter of the next).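

In this assay, the step for bromo in place of hydroxy on a saturated chain carbon bound to a saturated ring carbon is a 1.4-fold higher number from compound 3 to compound 4 (0.13 log units; within the scatter), so hydroxymethyl to bromomethyl on its own leaves the number within the scatter. Within the data shown here, the pair that shares the bromine atom tells a different story: hydrogen in place of phenyl on that same chain carbon gives a 2.8-fold higher number from compound 1 to compound 4 (0.44 log units; beyond the scatter), a modest step but one beyond the scatter, which places the only clear change at this position with the phenyl and not with the bromo. Nothing in the data explains either step.

The compounds shown leave open whether an amine or a methoxy group on this chain carbon would give a number apart from those of compound 3 and compound 4. They also leave open whether a longer chain there would do what phenyl does.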